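The source may hold more compounds than are shown below. What is called first, only, known or untested is meant among the compounds shown, and "the series" means these compounds.

Compound 1, `O=C(c1ccccn1)N1CCC(NS(=O)(=O)c2cc(S(=O)(=O)c3ccccc3)ccc2C(F)(F)F)CC1`, is tested in an assay on U2OS cells for inhibition of secreted frizzled-related protein 1 (Homo sapiens), read by a luciferase reporter, with a stated time of 18 h (a lower number here means that less compound is needed, a higher number that more compound is needed for the effect), where compound 1 gives 230 nM. Among the three compounds measured, compound 1 stands second highest. Compound 2, `O=C(O)c1ccc(S(=O)(=O)N2CCC(NS(=O)(=O)c3cc(S(=O)(=O)c4ccccc4)ccc3C(F)(F)F)CC2)cc1`, gives 110 nM in this assay, and compound 3, `CC(C)(O)CCN1CCC(NS(=O)(=O)c2cc(S(=O)(=O)c3ccccc3)ccc2C(F)(F)F)CC1`, gives 630 nM. Both differ from compound 1 only at the amine nitrogen in the ring, where the (pyridin-2-yl)carbonyl group is exchanged: the change a 2.1-fold lower number from compound 1 to compound 2 (0.32 log units; beyond the scatter) goes down by a modest amount, while a 2.7-fold higher number from compound 1 to compound 3 (0.44 log units; beyond the scatter) goes up by a modest amount.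

Compound 4, `CC(C)(C)OC(=O)N1CC[C@@H](C(=O)N2CCC(NS(=O)(=O)c3cc(S(=O)(=O)c4ccccc4)ccc3C(F)(F)F)CC2)C1`, keeps the carbonyl on that nitrogen and changes what sits on the carbonyl carbon: 1-(tert-butoxycarbonyl)pyrrolidin-3-yl in place of pyridin-2-yl on a carbonyl carbon. For the measured compounds named here, no measured pair makes exactly this kind of exchange, since the known steps remove the whole group rather than only the ring on its carbonyl. They do show, though, that this end of the shared core accepts different groups with only modest shifts in either direction. A step of similar size is therefore expected for compound 4, most likely a slight rise, so the estimated step is a 1.4-fold higher number from compound 1 to compound 4 (0.14 log units; within the scatter). For compound 4 the expected value in this assay is 320 nM, with a range from 110 nM to 900 nM.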

Compound 4, half-maximal effective concentration: 80 nM
Compound 4: middle estimate off by 4.0-fold (0.60 log units), on the high side; the measured number lies below the stated range.
By their numbers in this assay, from the lowest: compounds 4 and 2 (each within the scatter of the next); then compound 1; then compound 3.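

With the carbonyl kept on the ring nitrogen, replacing only the group on its carbon gives a 2.9-fold lower number from compound 1 to compound 4 (0.46 log units; beyond the scatter) in this assay, so an aromatic ring is not required on this carbonyl carbon, and a five-membered non-aromatic ring carrying a tert-butoxycarbonyl group, with 12 heavy atoms in place of 6, is accepted here. A carboxylic acid is also not needed for a number this low: compound 2, which carries one, gives 110 nM, while compound 4, which has none, gives 80 nM, and these two values lie within the usual scatter of each other. The data shown offer no measurement that explains why the number falls with this exchange.

From the compounds shown here alone, it remains open whether the lower number goes with the pyrrolidine ring or with the tert-butoxycarbonyl group, a question that a pyrrolidin-3-yl bearing a free secondary amine on the ring could separate. The opposite spatial arrangement at the one defined stereocentre would show whether that centre matters for the number in this assay.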